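Shortening a linker in a series of mGlu2 modulators

The compounds below may be only part of what the source reports. "The series", "measured", "known", "first", "only" and "open" are said of these compounds alone.

Of the compounds shown here, three have been measured in an assay on HEK293 cells for positive allosteric modulation of metabotropic glutamate receptor 2 (Rattus norvegicus), read by thallium flux, with a stated time of 2.5 min; on this read-out lower numbers stand for smaller maximal responses and higher numbers for larger maximal responses. Compound 2, with the structure `Cc1c(OCCCCOCOc2ccc(C(=O)O)cc2)ccc(C(=O)CC2CCCC2)c1O`, gives 95.4% in this assay, the highest of the three numbers. The nearest is compound 3, with the structure `CCCC(=O)c1ccc(OCCCCOc2cccc(C(=O)O)c2C)c(C)c1O`, which gives 82.4% in this assay, a gap beyond the scatter. Furthest is compound 1, with the structure `COc1cc(C(=O)O)ccc1OCCCCOc1ccc(C(=O)C(C)C)c(O)c1C`, which gives 73.1% in this assay, also beyond the scatter.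

Compound 4, with the structure `Cc1c(OCCCCOc2ccc(C(=O)O)cc2Cl)ccc(C(=O)CC2CCCC2)c1O`, has not been measured. It differs from compound 2 in one place: 4-carboxy-2-chlorophenyl in place of (4-carboxyphenoxy)methyl on an oxygen on a saturated carbon. The acid-bearing ring thus sits directly on the oxygen on a saturated carbon, as it does in compound 1 and compound 3, and it carries a chlorine.

For the measured compounds named here, with no measured step of this kind to lean on, the only guide is that compound 1 and compound 3, which also carry the acid ring directly on the chain oxygen, sit below compound 2. A modest downward step a number 10.4 percentage points lower from compound 2 to compound 4 (beyond the scatter) is therefore expected, at the edge of the scatter. Compound 4 is expected to give about 85% in this assay, within a range from 70% to 100%.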

Compound 4, largest response reached (reported as percent of maximum), in percent of the reference or control that the assay uses: 82.2%
Beside the measured number, compound 4's estimate is 2.8 percentage points above it; low and high end bracket the measured number.
By their numbers in this assay, from the lowest: compounds 1, 4 and 3 (each within the scatter of the next); then compound 2.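

In this assay, for the compounds shown here, the one change from compound 2 to compound 4, 4-carboxy-2-chlorophenyl in place of (4-carboxyphenoxy)methyl on an oxygen on a saturated carbon, gives a number 13.2 percentage points lower from compound 2 to compound 4 (beyond the scatter) and so shows that the maximal response depends on the group at this position. The response is reduced but not lost, as compound 4 still gives 82.2% in this assay, yet this single step combines two edits: the acid-bearing ring moves directly onto the oxygen, and a chlorine enters. No measurement here explains the drop.

Going by these compounds, how much of the step belongs to each edit remains open. A 4-carboxyphenyl group without the chlorine, on the same oxygen and the same core, would separate the two, and a fluorine or a methyl in place of the chlorine would test that atom further.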